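Shortening the chain and moving the chlorine in a sulfonamide series

The source may report more compounds than this note shows. Statements on the series, on what has been measured and on what is new or still open speak of the compounds shown alone.

Compound 1 `O=S(=O)(NCCCCNCc1ccc(Br)cc1)c1cc(C(F)(F)F)cc(C(F)(F)F)c1` is tested in a functional assay on A2780 cells (Homo sapiens) for inhibition, read by MTT assay, with a stated time of 72 h (a higher number here means a weaker inhibitor of growth, a lower number a stronger inhibitor of growth), where compound 1 gives 2100 nM, the highest of the two numbers shown. Compound 2 `O=S(=O)(NCCCNCc1ccc(Cl)cc1)c1cc(C(F)(F)F)cc(C(F)(F)F)c1` gives 1800 nM in this assay, and the step of a 1.2-fold lower number from compound 1 to compound 2 (0.07 log units; within the scatter) stays within the scatter. Compound 3 `O=S(=O)(NCCCNCc1cccc(Cl)c1)c1cc(C(F)(F)F)cc(C(F)(F)F)c1` differs from compound 1 by (3-chlorobenzyl)amino in place of ((4-bromobenzyl)amino)methyl on a saturated chain carbon, three bonds along the chain from a sulfonamide nitrogen. Among the compounds with values here, the only measured step that bears on this change is the one from compound 1 to compound 2; no measured pair shows the move of the chlorine on the ring. Compound 3 is therefore expected to show a step of a 1.1-fold lower number from compound 1 to compound 3 (0.02 log units; within the scatter), and its value in this assay is estimated at 2000 nM, within a range of 900 nM to 4500 nM.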

Compound 3, concentration for 50% growth inhibition: 2200 nM
For compound 3 the middle estimate is 1.1-fold (0.04 log units) below the measured one; low and high end bracket the measured number.
By their numbers in this assay, from the lowest: compounds 2, 1 and 3 (each within the scatter of the next).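

Moving the chlorine now has a measured pair: with 3-chlorophenyl in place of 4-chlorophenyl on a saturated chain carbon bound to an amine nitrogen, this assay shows a 1.2-fold higher number from compound 2 to compound 3 (0.09 log units; within the scatter). The broader change, (3-chlorobenzyl)amino in place of ((4-bromobenzyl)amino)methyl, gives a 1.0-fold higher number from compound 1 to compound 3 (0.02 log units; within the scatter), so it too stays within the scatter. Nothing shown here offers an explanation for these results.

The compounds shown leave open what a methoxy group in place of the chlorine would give. They also do not separate the shorter chain from the exchange of bromine for chlorine.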